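Swapping ethoxy for methylsulfonyl on a benzamide scaffold

A few compounds are considered here, and "the series" means these few. Any claim that something is new, unique, unknown or untested is made for them only; others in the source may bear on it.

Compound 1, `CCOc1ccc(CNC(=O)c2ccc(C(C)(C)C)cc2)cc1`, stands at the highest of the two numbers measured in an assay on HeLa cells with Bile acid receptor (Homo sapiens) as the target, read by a luciferase reporter, with a stated time of 24 h (on this read-out higher numbers stand for an effect only at larger amounts of compound and lower numbers for an effect already at smaller amounts), where compound 1 gives 160 nM. Compound 2, `CC(C)(C)c1ccc(C(=O)NCc2ccc(C(=O)O)cc2F)cc1`, reaches a much lower number, giving 7.8 nM in this assay, though the two structures differ in more than one place. Compound 3, `CC(C)(C)c1ccc(C(=O)NCc2ccc(S(C)(=O)=O)cc2)cc1`, is not yet measured; it is derived from compound 1 by methylsulfonyl in place of ethoxy on an aromatic carbon. Within the data shown here, no measured pair isolates this change, so the step is expected to be modest, toward a lower number, at a 2.0-fold lower number from compound 1 to compound 3 (0.30 log units; within the scatter). Compound 3 is therefore estimated at 80 nM, within 20 nM to 400 nM.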

Compound 3, half-maximal effective concentration: 3800 nM
The estimate for compound 3 lay 48-fold (1.68 log units) below the measured number, outside the stated range (above it).
By their numbers in this assay, from the lowest: compound 2; then compound 1; then compound 3.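

Exchanging ethoxy for methylsulfonyl on the aromatic carbon para to a large group gives a 24-fold higher number from compound 1 to compound 3 (1.38 log units; beyond the scatter) in this assay, so the outcome at this position depends strongly on the group it carries. Among these compounds, compound 2 differs from compound 1 in more than one place, so only this step isolates the position. Nothing measured here accounts for the size of this step.

From the compounds shown here alone, whether an amine, a nitrile or a longer alkoxy chain such as propoxy at this position would move the number in either direction remains open.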